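The source may report more compounds than this note shows. Statements on the series, on what has been measured and on what is new or still open speak of the compounds shown alone.

Compound 1 `ClCc1ccc(Cn2cnc3c(Cl)ncnc32)cc1` stands at the lower of the two numbers in hand: in a functional assay on DU-145 cells (Homo sapiens) for cytotoxicity, read by sulforhodamine B assay, with a stated time of 48 h (a lower number here means a stronger inhibitor of growth, a higher number a weaker inhibitor of growth), compound 1 gives 11800 nM. Compound 2 `ClCc1ccccc1Cn1cnc2c(Cl)ncnc21`, the other measured member, gives 34700 nM in this assay, a gap that lies beyond the scatter. Compound 3 `ClCc1ccc(Cn2cnc3c(Cl)nc(Cl)nc32)cc1` differs from compound 1 by chloro in place of hydrogen on an aromatic carbon. Among the compounds with values here, no measured pair shows what this change does in this assay, so only a small step is expected, a 1.3-fold lower number from compound 1 to compound 3 (0.12 log units; within the scatter), possibly none beyond the scatter in either direction. Compound 3 is estimated at 9000 nM in this assay, with a range from 3000 nM to 30000 nM.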

Compound 3, concentration for total growth inhibition: 17800 nM
Compound 3: the middle estimate sits 2.0-fold (0.30 log units) below what was measured; measured number inside the range.
By their numbers in this assay, from the lowest: compounds 1, 3 and 2 (each within the scatter of the next, the first and the last beyond it).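

In this assay, the carbon between two ring nitrogen atoms takes a chloro group in place of hydrogen with a 1.5-fold higher number from compound 1 to compound 3 (0.18 log units; within the scatter), so this single change leaves the number within the scatter. Compound 3 thus shows that this position accepts one chlorine atom without a step beyond the scatter, which compounds 1 and 2 alone could not show. No supporting data bear on why this is so. Still open, going by these compounds, is whether an amine or a methoxy group on this carbon would give a larger step, and whether the same chloro change would behave alike on the core of compound 2.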